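This account rests on a few compounds, and the source may have more. Where it says the series, first, only, none or still open, it means among the compounds named here.

Among the compounds with values here, in a physicochemical assay for lipophilicity, read by mass spectrometry (on this read-out higher numbers stand for higher lipophilicity and lower numbers for lower lipophilicity), compound 1 `COc1cccc(NC(=O)C2Cc3cc(OC)c(OC)cc3C2=O)c1` gives 2.08, while compound 2 `COc1cc2c(cc1OC)C(=O)C(C(=O)Nc1cccc(Cl)c1)C2` gives 2.76, the higher of the two numbers so far. Compound 3 `COc1cc2c(cc1OC)C(=O)C(C(=O)Nc1ccccc1F)C2` keeps the shared core but carries 2-fluorophenyl in place of 3-chlorophenyl on an amide-type nitrogen. Within the data shown here, only one measured step bears on this change: a number 0.68 log units higher from compound 1 to compound 2 (beyond the scatter), with chloro in place of methoxy on an aromatic carbon. That step shows how much one swap on this aromatic ring can move the number, and here the chloro group leaves again. Among the measured compounds shown here, no measured compound carries fluoro, however, so the guidance is rough. A downward step, smaller than the measured one, is expected in this assay, estimated as a number 0.36 log units lower from compound 2 to compound 3 (beyond the scatter). For compound 3 the estimated value is 2.4, with an expected range from 2.05 to 2.75.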

Compound 3, partition coefficient: 2.36
For compound 3 the middle estimate is 0.04 log units above the measured one; low and high end bracket the measured number.
By their numbers in this assay, from the lowest: compounds 1 and 3 (each within the scatter of the next); then compound 2.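

In this assay, 2-fluorophenyl in place of 3-chlorophenyl on the amide-type nitrogen gives a number 0.40 log units lower from compound 2 to compound 3 (beyond the scatter), so the number at this position responds to a change of halogen and its printed ring position made together. Set against 3-methoxyphenyl, the same 2-fluorophenyl group gives a number 0.28 log units higher from compound 1 to compound 3 (within the scatter), so this pair cannot be told apart here, whereas the 3-chlorophenyl group of compound 2 stands clear of both. Nothing available explains why these groups give these numbers.

On these data alone, since halogen and ring position change together in a single step, their separate shares remain unknown, and 3-fluorophenyl or 2-chlorophenyl would be needed to divide them. As far as these compounds go, how a ring carrying an amine or a carboxylic acid would read at this position also remains open.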